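The compounds below may be only part of what the source reports. "The series", "measured", "known", "first", "only" and "open" are said of these compounds alone.

Compound 2 `Cc1nn(-c2ncnc3nc[nH]c23)c2c1C(OC(=O)c1ccc(F)cc1)CC(=O)N2` carries the shared core with a (4-fluorophenyl)carbonyl on the oxygen on a saturated carbon. In a functional assay on HEK293 cells for agonist activity at G-protein coupled receptor 39 (Homo sapiens), read by scintillation proximity assay and inositol phosphate accumulation, with a stated time of 75 min (a lower number here means that less compound is needed, a higher number that more compound is needed for the effect), compound 2 gives 245 nM. Of the two numbers measured this is the larger, but only nominally: compound 1 `Cc1nn(-c2ncnc3nc[nH]c23)c2c1C(OCc1ccc(Cl)cc1Cl)CC(=O)N2` gives 243 nM in this assay, and the step of a 1.0-fold higher number from compound 1 to compound 2 (0.00 log units; within the scatter) lies within the scatter, so the two compounds cannot be told apart. Compound 3 `COc1ccc(CCOC2CC(=O)Nc3c2c(C)nn3-c2ncnc3nc[nH]c23)cc1` differs from compound 2 in one place: 2-(4-methoxyphenyl)ethyl in place of (4-fluorophenyl)carbonyl on an oxygen on a saturated carbon. For the measured compounds named here, the only measured step that bears on this change is the one just described, where a different group on the same oxygen was exchanged without any shift beyond the scatter. A similar outcome is therefore expected here, that is, no step beyond the scatter in this assay, a 1.0-fold higher number from compound 2 to compound 3 (0.01 log units; within the scatter). Compound 3 is accordingly estimated at 250 nM, with a range from 80 nM to 800 nM.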

Compound 3, half-maximal effective concentration: 70 nM
The estimate for compound 3 lay 3.6-fold (0.55 log units) above the measured number, outside the stated range (below it).
By their numbers in this assay, from the lowest: compound 3; then compounds 1 and 2 (each within the scatter of the next).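

The group on this oxygen can matter after all: in this assay 2-(4-methoxyphenyl)ethyl in place of (4-fluorophenyl)carbonyl gives a 3.5-fold lower number from compound 2 to compound 3 (0.54 log units; beyond the scatter) and 4-methoxybenzyl in place of 2,4-dichlorophenyl on the saturated chain carbon gives a 3.5-fold lower number from compound 1 to compound 3 (0.54 log units; beyond the scatter) as well. The earlier tie between two quite different groups therefore did not mean that every group serves equally at this position. Nothing available explains why this particular group needs less compound for the effect.

With only one ether of this kind carrying a methoxy group, the compounds shown cannot say whether the gain belongs to the methoxy group or to the chain that carries the ring. As far as these compounds go, how a longer chain, or an amine or a carboxylic acid in place of the methoxy group, would behave here remains open.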